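The source may hold more compounds than are shown below. What is called first, only, known or untested is meant among the compounds shown, and "the series" means these compounds.

In an ADME assay on the whole organism with Oryza sativa as the target, tested at 10 uM (a higher number here means a weaker effect of the compound at the concentration tested, a lower number a stronger effect), compound 2 `COc1cccc(NC(=O)N[C@H](C)c2ccccc2)c1` gives 70%, the highest of the two numbers shown; compound 1 `Cc1cccc(NC(=O)N[C@H](C)c2ccccc2)c1` gives 47%. Going by the values given here, the only measured step is a number 23 percentage points higher from compound 1 to compound 2 (beyond the scatter). Compound 3 `C[C@@H](NC(=O)Nc1cccc(Br)c1)c1ccccc1` differs from compound 2 by bromo in place of methoxy on an aromatic carbon. Among the compounds with values here, no measured step concerns a bromo group, so the one step from methyl to methoxy only shows that an exchange at this carbon can move the number beyond the scatter. A modest step downward is expected, since a bromo group shares no acceptor with methoxy. Compound 3 is therefore expected to give 55%, between 35% and 75%, an estimated step of a number 15 percentage points lower from compound 2 to compound 3 (beyond the scatter).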

Compound 3, a percentage reported as activity, at one concentration (the size of the read-out at that concentration, not a potency): 99%
Estimate against measurement, compound 3: 44 percentage points below; the measured number lies above the stated range.
By their numbers in this assay, from the lowest: compound 1; then compound 2; then compound 3.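

In this assay, bromo in place of methoxy on this aromatic carbon gives a number 29 percentage points higher from compound 2 to compound 3 (beyond the scatter), and bromo in place of methyl gives a number 52 percentage points higher from compound 1 to compound 3 (beyond the scatter) here. Compound 3 therefore shows the weakest effect of the three, and the exchange of bromo for methyl moves the number further than either other step at this carbon. Nothing measured here explains this order.

On these data alone, whether bromo is unusual at this carbon or other halogens behave alike remains open, as chloro or fluoro would show. As far as these compounds go, how an amine or a carboxylic acid at the same carbon would compare also remains open.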